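The compounds below may be only part of what the source reports. "The series", "measured", "known", "first", "only" and "open" are said of these compounds alone.

Measured so far in a physicochemical assay for lipophilicity; on this read-out lower numbers stand for lower lipophilicity and higher numbers for higher lipophilicity:

compound 1, `Cn1nccc1-c1cc(C(F)(F)F)ccc1[C@H]1CCc2cc(S(=O)(=O)Nc3ncccn3)ccc21`, gives 2.4
compound 2, `Cn1nccc1-c1cc(C(F)(F)F)ccc1[C@H]1CCOc2cc(S(=O)(=O)Nc3cccc(F)n3)ccc21`, gives 3.6
compound 3, `Cc1nc(-c2cc(C(F)(F)F)ccc2[C@H]2CCOc3cc(S(=O)(=O)Nc4cccc(F)n4)ccc32)co1`, gives 4

Compound 2 stands second highest of the three numbers in this assay; its nearest neighbour is compound 3, a number 0.40 log units higher from compound 2 to compound 3 (beyond the scatter), and its furthest is compound 1, which differs from compound 2 in more than one place and whose value lies well below it.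

Compound 4, `Cn1nccc1-c1cc(C(F)(F)F)ccc1[C@H]1CCOc2cc(S(=O)(=O)Nc3cnccn3)ccc21`, is not yet measured. It differs from compound 2 in one place: pyrazin-2-yl in place of 6-fluoropyridin-2-yl on a sulfonamide nitrogen. Going by the values given here, the only measured step, a number 0.40 log units higher from compound 2 to compound 3 (beyond the scatter), concerns an exchange on an aromatic carbon elsewhere in the core and does not bear on the sulfonamide nitrogen. Among the compounds with values here, no measured step covers a change at that position, so the expectation rests on the structural change alone. A modest downward step is expected, a number 0.70 log units lower from compound 2 to compound 4 (beyond the scatter), beyond the scatter but not approaching the gap down to compound 1. Compound 4 is therefore estimated at 2.9 in this assay, within a range from 2.3 to 3.5.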

Compound 4, distribution coefficient: 1.8
Compound 4: middle estimate off by 1.10 log units, on the high side, and the stated range ends above it.
By their numbers in this assay, from the lowest: compound 4; then compound 1; then compound 2; then compound 3.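

In this assay, the sulfonamide nitrogen proves to be a sensitive position, with pyrazin-2-yl in place of 6-fluoropyridin-2-yl giving a number 1.80 log units lower from compound 2 to compound 4 (beyond the scatter) in a single exchange. Going by these compounds alone, this is the first step read at this position, and it runs opposite in direction to a number 0.40 log units higher from compound 2 to compound 3 (beyond the scatter) on an aromatic carbon. Nothing measured in this set accounts for the size of the new step.

The exchange removes the fluorine and adds a ring nitrogen together, so the compounds shown leave open which of the two changes carries the step, and plain pyridin-2-yl on the sulfonamide nitrogen would separate them. Also open, going by these compounds, is whether pyrazin-2-yl gives a step of similar size alongside 2-methyl-1,3-oxazol-4-yl, as in compound 3, or on the core of compound 1.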